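Rearranging the amide-bearing chain of compound 2

This account rests on a few compounds, and the source may have more. Where it says the series, first, only, none or still open, it means among the compounds named here.

Measured compounds:
compound 1, `CN(C)C(=O)c1cc2cnc(Nc3ccc(C(=O)NCCCN=C=S)cc3)nc2n1C1CCCC1`, 91.2%
compound 2, `CN(C)C(=O)c1cc2cnc(Nc3ccc(C(=O)NCCCCN=C=S)cc3)nc2n1C1CCCC1`, 74.2%
compound 3, `CN(C)C(=O)c1cc2cnc(Nc3ccc(C(=O)NCCCCN=C=S)cc3O)nc2n1C1CCCC1`, 51.8%

These three compounds share one core and were tested in a functional assay on NCI-H1299 cells (Homo sapiens) for inhibition, read by CCK-8 assay, with a stated time of 72 h, tested at 10 uM; a lower number here means a weaker effect, a higher number a stronger effect of the compound at the concentration tested. Compound 1 gives 91.2%, compound 2 gives 74.2% and compound 3 gives 51.8%. Compound 2 stands second highest of the three: its nearest neighbour is compound 1, which lies a number 17 percentage points lower from compound 1 to compound 2 (beyond the scatter), and its furthest is compound 3, which lies a number 22.4 percentage points lower from compound 2 to compound 3 (beyond the scatter).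

Compound 4, `CN(C)C(=O)c1cc2cnc(Nc3ccc(NC(=O)CCCCN=C=S)cc3)nc2n1C1CCCC1`, is not yet measured. It differs from compound 2 by a group of 10 heavy atoms (6 carbon, 2 nitrogen, 1 oxygen, 1 sulfur; no ring) in place of a group of 10 heavy atoms (6 carbon, 2 nitrogen, 1 oxygen, 1 sulfur; no ring), on an aromatic carbon; the two have the same atoms, joined differently, and the change sits on an aromatic carbon of a six-membered aromatic ring of carbon only, para to a large group.

Neither measured step bears directly on this rearrangement. The step from compound 1 to compound 2, a chain lengthening, was modest, as was the step from compound 2 to compound 3, a hydroxy replacing hydrogen; both pointed downward. For the measured compounds named here, as no measured pair reports a change of this kind, the step from compound 2 to compound 4 is expected to fall within the scatter, estimated as a number 4.2 percentage points lower from compound 2 to compound 4 (within the scatter). For compound 4 the expected value in this assay is 70%, with a range from 50% to 88%.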

Compound 4, a percentage reported as inhibition, at one concentration (the size of the read-out at that concentration, not a potency): 82.5%
Estimate against measurement, compound 4: 12.5 percentage points below; measured number inside the range.
By their numbers in this assay, from the lowest: compound 3; then compounds 2, 4 and 1 (each within the scatter of the next, the first and the last beyond it).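

Joining the same atoms the other way round, so that the amide is reversed on the aromatic carbon para to a large group, gives a number 8.3 percentage points higher from compound 2 to compound 4 (within the scatter) in this assay and is the first change in this series that leaves the read-out within the scatter, whereas the chain lengthening and the added hydroxy each gave a step beyond it. Compound 4 is also close to the compound with the shorter chain, as a number 8.7 percentage points lower from compound 1 to compound 4 (within the scatter) shows, so it cannot be separated from either compound 1 or compound 2, even though those two lie beyond the scatter of each other. The orientation of the amide therefore shows no clear effect of its own here, and nothing available explains why the read-out holds up after the rearrangement.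

As far as these compounds go, the reversed amide appears here with only one chain, so it remains open how it would behave with a shorter or longer chain, or with a hydroxy on the same ring as in compound 3. Also open, from the compounds shown here alone, is whether a urea or sulfonamide linkage, or a terminal amine in place of the chain end, would keep the read-out, and all these numbers describe a single concentration rather than a potency.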